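The source may hold more compounds than are shown below. What is called first, only, known or untested is meant among the compounds shown, and "the series" means these compounds.

Series notes, step from compound 1 to compound 3.

Compound 1 `NC1CCC(Nc2nc(NCc3ccc(-c4ccccc4)cc3)c3ncn(C4CCCC4)c3n2)CC1` gives in a functional assay on HOS cells (Homo sapiens) for inhibition, with a stated time of 72 h (a higher number here means a weaker inhibitor, a lower number a stronger inhibitor), a half-maximal inhibitory concentration of 290 nM. Within the data shown here, that is the highest of the two numbers so far measured; the nearest is compound 2 `NC1CCC(Nc2nc(NCc3ccc(-c4cccc(F)c4)nc3)c3ncn(C4CCCC4)c3n2)CC1`, which in this assay gives 44 nM, a gap that lies beyond the scatter. Among the measured compounds shown here, no pair of measured compounds differing in a single place is available, so no measured step can be read off directly.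

Compound 3 `Nc1ccccc1CNc1nc(NC2CCC(N)CC2)nc2c1ncn2C1CCCC1` has not yet been measured. It differs from compound 1 as follows: 2-aminophenyl in place of 4-phenylphenyl on a saturated chain carbon bound to a nitrogen on an aromatic ring. The change removes one of the two six-membered aromatic rings of carbon only and brings in one hydrogen-bond donor and one hydrogen-bond acceptor that compound 1 lacks on this side of the shared core.

For the measured compounds named here, with no comparable measured step to lean on, a modest step toward a higher number in this assay is expected, of a size that may just reach beyond the scatter; the step from compound 1 to compound 3 is estimated at a 2.1-fold higher number from compound 1 to compound 3 (0.32 log units; beyond the scatter). On that basis compound 3 is expected to give about 600 nM, with a range from 150 nM to 2500 nM.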

Compound 3, half-maximal inhibitory concentration: 2030 nM
Beside the measured number, compound 3's estimate is 3.4-fold (0.53 log units) below it; low and high end bracket the measured number.
By their numbers in this assay, from the lowest: compound 2; then compound 1; then compound 3.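

At the place on a saturated chain carbon bound to a nitrogen on an aromatic ring, the series now has its first comparison of compounds differing in one place. In this assay the exchange of 4-phenylphenyl for 2-aminophenyl brings a 7.0-fold higher number from compound 1 to compound 3 (0.85 log units; beyond the scatter) and so shows that the number depends on the group held at this place. The exchange removes one six-membered aromatic ring of carbon only and adds a hydrogen-bond donor and acceptor together, so the step belongs to the whole change and cannot be divided among these parts, and nothing at hand bears on its origin.

Plain phenyl at this place would separate the loss of the second ring from the arrival of the amine, while a carboxylic acid in place of the amine would show whether the step depends on that particular group. Steps involving compound 2 cannot be read, as it differs from compound 1 and compound 3 in more than one place, so its fluorine-bearing group cannot yet be placed alongside this change.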